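The source may report more compounds than this note shows. Statements on the series, on what has been measured and on what is new or still open speak of the compounds shown alone.

Of the compounds shown here, three sharing one core have been measured: compound 1 `CCC#Cc1c[nH]c(=O)[nH]c1=O`, compound 2 `CCCCCCC#Cc1c[nH]c(=O)[nH]c1=O` and compound 3 `O=c1[nH]cc(C#CC(O)c2ccccc2)c(=O)[nH]1`. In an ADME assay on Vero cells (Chlorocebus sabaeus) for cytotoxicity, read by MTT assay (a lower number here means that less compound is tolerated, a higher number that more compound is tolerated), compound 1 gives 263000 nM, compound 2 gives 250000 nM and compound 3 gives 242000 nM. On these three numbers compound 2 cannot be set apart from either neighbour, since its value lies within the scatter of both compound 1 and compound 3. Going by the values given here, the one step that can be traced in one place is a 1.1-fold lower number from compound 1 to compound 2 (0.02 log units; within the scatter), so lengthening the chain that hangs from the triple bond left the tolerated concentration unchanged within the scatter.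

Compound 4 `CCCCC#Cc1c[nH]c(=O)[nH]c1=O` is the next case. Compared with compound 2 the change is hydrogen in place of ethyl on a saturated chain carbon, four bonds along the chain from a triple-bonded carbon. This is the same kind of chain shortening or lengthening as the step from compound 1 to compound 2, only smaller, and compound 4 carries a chain that in length falls between those of compound 1 and compound 2. Since that earlier step stayed within the scatter, the expected step in this assay is a 1.0-fold higher number from compound 2 to compound 4 (0.01 log units; within the scatter), that is, none beyond the scatter. Compound 4 is therefore expected to give about 255000 nM, with a likely range from 150000 nM to 420000 nM.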

Compound 4, half-maximal cytotoxic concentration: 253000 nM
For compound 4 the middle estimate is 1.0-fold (0.00 log units) above the measured one; the measured number falls inside the stated range.
By their numbers in this assay, from the lowest: compounds 3, 2, 4 and 1 (each within the scatter of the next).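

In this assay, hydrogen in place of ethyl on a saturated chain carbon, four bonds along the chain from a triple-bonded carbon, gives a 1.0-fold higher number from compound 2 to compound 4 (0.01 log units; within the scatter), and extending the chain by ethyl gives a 1.0-fold lower number from compound 1 to compound 4 (0.02 log units; within the scatter). Going by these compounds alone, until now, only one step along the plain carbon chain could be read, whereas compound 1, compound 4 and compound 2 now form a series of three chain lengths in which every step stays within the scatter, at both places on the chain. The information at hand offers no explanation for why these three chains cannot be told apart.

As far as these compounds go, whether this holds only for plain carbon chains remains open, since an amine or a carboxylic acid at the end of the chain could give a different result in this assay. From the compounds shown here alone, it is also open whether a much longer chain, or a ring joined directly to the triple bond, would stay within the scatter of compound 1, compound 2 and compound 4.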